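A few compounds are considered here, and "the series" means these few. Any claim that something is new, unique, unknown or untested is made for them only; others in the source may bear on it.

In a functional assay on HCT-116 cells (Homo sapiens) for cytotoxicity, read by MTT assay (on this read-out lower numbers stand for stronger inhibition and higher numbers for weaker inhibition), two compounds have been measured so far. Compound 1 `Nc1ccccc1NC(=O)c1ccc(CNc2nc3ccccc3[nH]2)cc1` gives 300 nM and compound 2 `COc1ccc2nc(SCc3ccc(C(=O)Nc4ccccc4N)cc3)[nH]c2c1` gives 200 nM, so compound 1 stands level with compound 2, the two values lying within the usual scatter of repeated measurements. Compound 3 `Nc1ccccc1NC(=O)c1ccc(CNc2ncc(Br)s2)cc1` departs from compound 1 by one change on an amine nitrogen: 5-bromo-1,3-thiazol-2-yl in place of 1H-benzimidazol-2-yl on an amine nitrogen. Going by the values given here, the two measured compounds do not differ in one place only, so no measured step is available to gauge this exchange. A moderate move towards a higher number in this assay is expected, though the data cannot show whether it will clear the scatter. The expected size of the change is a 2.0-fold higher number from compound 1 to compound 3 (0.30 log units; within the scatter). Compound 3 is estimated at 600 nM, with an expected range from 150 nM to 2500 nM.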

Compound 3, half-maximal inhibitory concentration: 400 nM
For compound 3 the middle estimate is 1.5-fold (0.18 log units) above the measured one; the range from low to high includes it.
By their numbers in this assay, from the lowest: compounds 2, 1 and 3 (each within the scatter of the next).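

In this assay, 5-bromo-1,3-thiazol-2-yl in place of 1H-benzimidazol-2-yl on the amine nitrogen gives a 1.3-fold higher number from compound 1 to compound 3 (0.12 log units; within the scatter), so this exchange produces no readable shift. The position thus accepts a group with a single five-membered aromatic ring, carrying sulfur and bromine and no hydrogen-bond donor, in place of one that also has a six-membered aromatic ring of carbon only, with the values staying level. Nothing measured here explains why the two groups read alike.

From the compounds shown here alone, what a 1,3-thiazol-2-yl without the bromine would give on this amine nitrogen stays open, so the part played by the bromine cannot be judged. Going by these compounds, whether a pyridin-2-yl or a plain methyl at the same place would hold its value in this assay also remains open.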